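From compound 2 to compound 3: an aryl exchange

The source may hold more compounds than are shown below. What is called first, only, known or untested is meant among the compounds shown, and "the series" means these compounds.

In an ADME assay on HT-29 cells (Homo sapiens) for cytotoxicity, read by MTT assay, with a stated time of 72 h (on this read-out higher numbers stand for weaker inhibition and lower numbers for stronger inhibition), compound 1 `COc1cc(C2=C(c3cc(C)c(OC)c(C)c3)C(O)CC2=O)cc(OC)c1OC` gives > 100 ug/mL as a limit of the assay. Compound 2 `COc1ccc(C2=C(c3cc(OC)c(OC)c(OC)c3)C(=O)CC2O[SiH2]C(C)(C)C)cc1OC` gives > 100 ug/mL as a limit too. Compound 2 thus stands at the limit of > 100 ug/mL in this assay, at which 2 of the 2 values shown sit, and has no number of its own. Compound 3 `COc1cc(C2=C(c3cc(C)c(OC)c(C)c3)C(O[SiH2]C(C)(C)C)CC2=O)cc(OC)c1OC` carries 4-methoxy-3,5-dimethylphenyl in place of 3,4-dimethoxyphenyl on a double-bonded ring carbon and is otherwise the same as compound 2. For the measured compounds named here, with no measured step, the expected step that the limit leaves unreadable from compound 2 to compound 3 in this assay is none beyond the scatter in either direction. For compound 3 the estimated value is 150 ug/mL with an expected range from 60 ug/mL to 400 ug/mL and a limit reading is likely.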

Compound 3, half-maximal inhibitory concentration: 10 ug/mL
Compound 3: middle estimate off by 15-fold (1.18 log units), on the high side, and the stated range ends above it.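

In this assay, 4-methoxy-3,5-dimethylphenyl in place of 3,4-dimethoxyphenyl on a double-bonded ring carbon gives an at least 10-fold lower number from compound 2 to compound 3 (1.00 log units; beyond the scatter). The group of 5 heavy atoms in place of a hydrogen atom, on an oxygen on a saturated carbon, also gives an at least 10-fold lower number from compound 1 to compound 3 (1.00 log units; beyond the scatter), and of the compounds shown only compound 3 carries both this group and 4-methoxy-3,5-dimethylphenyl. Each step starts from a limit of the assay, not a number, so its full size cannot be read: the limit of > 100 ug/mL in this assay, at which 2 of the 3 values shown sit.

Open, from the compounds shown here alone, is whether an amine or a longer chain in place of the group of 5 heavy atoms holds the value of compound 3 at 10 ug/mL.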